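Removing One Methoxy Group: Expectation for Compound 4

A few compounds are considered here, and "the series" means these few. Any claim that something is new, unique, unknown or untested is made for them only; others in the source may bear on it.

Compound 1 `COc1cc(-c2cc(/C=C/C(=O)c3ccc(N)cc3)[nH]n2)cc(OC)c1OC` gives 76% in a functional assay on A498 cells (Homo sapiens) for cytotoxicity, read by sulforhodamine B assay, with a stated time of 48 h, tested at 1 uM; on this read-out higher numbers stand for a weaker effect at the one concentration tested and lower numbers for a stronger effect.
Compound 2 `COc1ccc(C(=O)/C=C/c2cc(-c3cc(OC)c(OC)c(OC)c3)n[nH]2)cc1OC` gives 78% in this assay.
Compound 3 `COc1ccc(C(=O)/C=C/c2cc(-c3cc(OC)c(OC)c(OC)c3)n[nH]2)cc1` gives 84% in this assay.

All three values lie within the usual scatter of one another, so no order among them can be drawn. Compound 4 `COc1ccc(-c2cc(/C=C/C(=O)c3ccc(N)cc3)[nH]n2)cc1OC` has not been measured. It differs from compound 1 by hydrogen in place of methoxy on an aromatic carbon. The same kind of change separates compound 2 from compound 3, (hydrogen in place of methoxy on an aromatic carbon), where it made a step of a number 6 percentage points higher from compound 2 to compound 3 (within the scatter). The two cores differ by 4-aminophenyl in place of 3,4-dimethoxyphenyl on a carbonyl carbon, and the surroundings of the place are not identical: in compound 1 the carbon is also meta to a methoxy group (2 heavy atoms). From compound 1 to compound 4 a step of about a number 6 percentage points higher from compound 1 to compound 4 (within the scatter) is expected, resting on a number 6 percentage points higher from compound 2 to compound 3 (within the scatter). Compound 4 is therefore estimated at 82%, between 70% and 93%.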

Compound 4, a percentage reported as activity, at one concentration (the size of the read-out at that concentration, not a potency): 89%
Compound 4: middle estimate off by 7 percentage points, on the low side, within the range that was stated.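

On the core of compound 1, hydrogen in place of methoxy gives a number 13 percentage points higher from compound 1 to compound 4 (beyond the scatter) in this assay at the one concentration tested. This step cannot be told apart from the step made by the same change on the other core: the same change on two cores in this assay, a number 6 percentage points higher (within the scatter) from compound 2 to compound 3 and a number 13 percentage points higher (beyond the scatter) from compound 1 to compound 4, 7 percentage points apart, within the scatter of two such steps. So nothing here shows that the core alters the effect of the change, but two cores cannot establish a general rule, and these numbers do not explain the steps or give a potency.

At this place on the ring, the compounds shown carry only methoxy or hydrogen. On these data alone, how a hydroxyl group, an ethoxy group or a chlorine atom there would behave remains open.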